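Swapping the aryl group on the piperazine nitrogen: predicting compound 4

The compounds below may be only part of what the source reports. "The series", "measured", "known", "first", "only" and "open" are said of these compounds alone.

The measured compounds and their numbers:
Compound 1, `COc1ccc(N2CCN(Cn3nc(Cc4ccc(SC)cc4)oc3=S)CC2)cc1`: 33.7%
Compound 2, `CSc1ccc(Cc2nn(CN3CCN(c4ccc(Cl)cc4)CC3)c(=S)o2)cc1`: 71.1%
Compound 3, `CSc1ccc(Cc2nn(CN3CCN(c4cccc(Cl)c4)CC3)c(=S)o2)cc1`: 74.7%

In a functional assay on the whole organism (strain Wister albino) for inhibition, with Rattus norvegicus as the target, read by paw edema, with stated times of 30 min and 3 h, at a dose of 10 mg/kg by the oral route (a higher number here means more inhibition at the dose given (going by the name of the read-out), a lower number less inhibition), compound 3 gives 74.7%, the highest of the three numbers; its nearest neighbour is compound 2, and the gap a number 3.6 percentage points higher from compound 2 to compound 3 (within the scatter) lies within the scatter, so the two cannot be ranked. Compound 1 is far behind, as a number 41 percentage points higher from compound 1 to compound 3 (beyond the scatter) shows.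

Compound 4, `CSc1ccc(Cc2nn(CN3CCN(c4ccc([N+](=O)[O-])cc4)CC3)c(=S)o2)cc1`, is not yet measured. It differs from compound 3 in one place: 4-nitrophenyl in place of 3-chlorophenyl on an amine nitrogen in a ring

Within the data shown here, the steps that bear on this change are those that alter the same aryl group. Both a number 37.4 percentage points higher from compound 1 to compound 2 (beyond the scatter) and a number 41 percentage points higher from compound 1 to compound 3 (beyond the scatter) were large, while a number 3.6 percentage points higher from compound 2 to compound 3 (within the scatter) was within the scatter. None of them involves a nitro group, so the direction for compound 4 rests on little. The expectation is that compound 4 gives 60%, within 35% to 80%. That estimate corresponds to a number 14.7 percentage points lower from compound 3 to compound 4 (beyond the scatter), a step expected to be modest and downward but uncertain in size.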

Compound 4, a percentage reported as inhibition, in the whole organism at one dose (the size of the read-out at that dose, not a potency): 56.6%
The estimate for compound 4 lay 3.4 percentage points above the measured number; the range from low to high includes it.
By their numbers in this assay, from the lowest: compound 1; then compound 4; then compounds 2 and 3 (each within the scatter of the next).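

In this assay the 4-nitrophenyl group separates compound 4 from both chlorophenyl compounds, with a number 18.1 percentage points lower from compound 3 to compound 4 (beyond the scatter) and a number 14.5 percentage points lower from compound 2 to compound 4 (beyond the scatter) on the same amine nitrogen in a ring. It also keeps compound 4 clear of the methoxy compound, with a number 22.9 percentage points higher from compound 1 to compound 4 (beyond the scatter) as the step, so chloro, nitro and methoxy on the aromatic carbon of this aryl group give three distinct levels, and a nitro group retains part of the inhibition seen with chloro. Nothing measured here explains this order.

Whether the nitro group would show the same lack of separation between its two ring positions that the chlorophenyl pair shows remains open, as 3-nitrophenyl does not appear among these compounds. Also open, from the compounds shown here alone, is how an unsubstituted phenyl ring, a carboxylic acid or an amine on the ring would fall relative to these three levels.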